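An Amino Group Added to Compound 1

The compounds below may be only part of what the source reports. "The series", "measured", "known", "first", "only" and "open" are said of these compounds alone.

In a physicochemical assay for acid dissociation, three compounds have been measured so far. Compound 1 (`NS(=O)(=O)c1ccc(S(=O)(=O)CCCO)cc1`) gives 8.98, the lowest of the three numbers. Compound 2 (`NS(=O)(=O)c1ccc(SCCCO)c(Cl)c1`) gives 9.45, and compound 3 (`NS(=O)(=O)c1ccc(SCCO)c(F)c1`) gives 9.76. Both of these stand above compound 1 by more than the usual scatter.

Compound 4 (`Nc1cc(S(N)(=O)=O)ccc1S(=O)(=O)CCCO`) has not yet been measured. It differs from compound 1 in a single place: amino in place of hydrogen on an aromatic carbon. This is amino in place of hydrogen on an aromatic carbon, ortho to a group of 7 heavy atoms and meta to a sulfamoyl group.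

Going by the values given here, no two measured compounds differ in only one place, so the data give no direct measure of what such a change does. The expectation therefore starts from compound 1 at 8.98. It is expected to stay well under the number of compound 3, which gives 9.76. A small rise is expected, one that may not go beyond the scatter. The estimate is a number 0.12 log units higher from compound 1 to compound 4 (within the scatter). For compound 4 the estimated value is 9.1, with an expected range from 8.8 to 9.5.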

Compound 4, acid dissociation constant: 9.15
Estimate against measurement, compound 4: 0.05 log units below, within the range that was stated.
By their numbers in this assay, from the lowest: compounds 1, 4 and 2 (each within the scatter of the next, the first and the last beyond it); then compound 3.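

In this assay, going by these compounds alone, the change of amino in place of hydrogen on an aromatic carbon, ortho to a group of 7 heavy atoms and meta to a sulfamoyl group, gives a number 0.17 log units higher from compound 1 to compound 4 (within the scatter) and is the first step in this set that can be read between two compounds differing in one place. At this place on the core of compound 1, then, adding an amino group, with its one nitrogen and its hydrogen-bond donor and acceptor, leaves the number indistinguishable from that of the parent. No measurement shown here bears on why the read-out stays within the scatter for this change.

The compounds shown leave open whether a different group at this same place, such as a methyl, a hydroxyl or a carboxylic acid, would also stay within the scatter of compound 1. They also leave open whether an amino group would give a step of similar size at another carbon of the six-membered aromatic ring, or on a compound with a longer chain.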